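Swapping the Amide-Capped Ring for a Thiomorpholine

The compounds below may be only part of what the source reports. "The series", "measured", "known", "first", "only" and "open" are said of these compounds alone.

Compound 1 `CC(C)(C)c1cc(NC(=O)[C@@H]2CCCCN2C(=O)C2CCOCC2)no1` and compound 2 `CCC(=O)N1CCN(C(=O)N2CCCC[C@H]2C(=O)Nc2cc(C(C)(C)C)on2)CC1` share the same core and differ only in the group attached to a carbonyl carbon. In an ADME assay (liver) for metabolic stability, with Liver microsome (Homo sapiens) as the target, read by LC-MS, using microsomes and NADPH, tested at 1 uM (a higher number here means that the compound lasts longer, a lower number that the compound disappears faster), compound 1 reaches a value recorded only as a limit of the assay, > 2 h. In this assay compound 2 likewise stops at a limit, > 2 h. Both results rest at the limit of > 2 h in this assay, at which 2 of the 2 values shown sit, so the step that the two limits leave unreadable from compound 1 to compound 2 cannot be sized, and compound 2 stands at the limit with no number of its own beneath it.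

Compound 3 `CC(C)(C)c1cc(NC(=O)[C@@H]2CCCCN2C(=O)N2CCSCC2)no1` follows from compound 2 by a single change, (thiomorpholin-4-yl in place of 4-propanoylpiperazin-1-yl on a carbonyl carbon). For the measured compounds named here, the only measured step bears on this change insofar as it also swapped the ring on that carbonyl carbon, yet it was unreadable and gives neither a size nor a direction. Going by the values given here, nothing among the measured compounds points to a loss beyond the scatter. For compound 3 the half-life is therefore expected to be 2.5 h, between 1 h and 6 h. The expected step that the limit leaves unreadable from compound 2 to compound 3 is no step beyond the scatter, most likely ending again at a limit.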

Compound 3, half-life in the Liver microsome assay: < 0.0834 h
Compound 3 was reported as a limit (the forecaster's own chance of this, stated with the estimate: 65%); middle value at least 29-fold (1.47 log units) from the limit.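

In the Liver microsome assay compound 3 gives < 0.0834 h, which is a limit of the assay. The earlier pair gave no readable step at this position, but in the Liver microsome assay thiomorpholin-4-yl in place of 4-propanoylpiperazin-1-yl now gives an at least 23-fold lower number from compound 2 to compound 3 (1.37 log units; beyond the scatter), and thiomorpholin-4-yl in place of oxan-4-yl gives an at least 23-fold lower number from compound 1 to compound 3 (1.37 log units; beyond the scatter). The group on this carbonyl carbon therefore matters: the shared core alone does not secure a long half-life, and the ring placed there can decide it. In a physicochemical assay for solubility, read by HPLC, at pH 6.8 (a higher number here means a more soluble compound, a lower number a less soluble compound), compound 2 gives 68 ug/mL and compound 3 gives 46 ug/mL. In the physicochemical assay the same change gives a 1.5-fold lower number from compound 2 to compound 3 (0.17 log units; within the scatter), so the two read-outs part ways here, with a large step in one and a step within the scatter in the other.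

The half-lives of all three compounds rest on limits, so the steps to compound 3 have no exact size and the step between compound 1 and compound 2 cannot be read at all: the limit of > 2 h in the Liver microsome assay, at which 2 of the 3 values shown sit.

Going by these compounds, it also stays open whether the sulfur matters or the ring as a whole, a question that morpholin-4-yl, which carries an oxygen instead of the sulfur, or piperidin-1-yl, which carries a carbon instead, could help to settle.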